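A second chlorine on the phenyl of the shared core

A few compounds are considered here, and "the series" means these few. Any claim that something is new, unique, unknown or untested is made for them only; others in the source may bear on it.

compound 1 `Fc1cccc(N2CCN(CCCCOc3ccc4c(c3)CCC4)CC2)c1` — 17%
compound 2 `Clc1ccc(N2CCN(CCCCOc3ccc4c(c3)CCC4)CC2)cc1` — 33%

In a functional assay on the whole organism for inhibition, with Mus musculus as the target, at a dose of 25 mg/kg by the oral route (a lower number here means less inhibition, a higher number more inhibition at the dose given (going by the name of the read-out)), compound 2 gives 33%, the higher of the two measured values, while compound 1 gives 17%. Going by the values given here, the only measured step is a number 16 percentage points higher from compound 1 to compound 2 (beyond the scatter). Compound 3 `Clc1cc(Cl)cc(N2CCN(CCCCOc3ccc4c(c3)CCC4)CC2)c1` carries the change (3,5-dichlorophenyl in place of 4-chlorophenyl on an amine nitrogen in a ring). Among the compounds with values here, no measured step exchanges one chlorine for two on this phenyl, so the single known step bears on it only loosely, showing that a change of this phenyl can move the read-out modestly. A step of about a number 2 percentage points higher from compound 2 to compound 3 (within the scatter) is expected, not beyond the scatter. Compound 3 is estimated at 35%, with a range from 15% to 55%.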

Compound 3, a percentage reported as inhibition, in the whole organism at one dose (the size of the read-out at that dose, not a potency): 0%
Estimate against measurement, compound 3: 35 percentage points above; measured number outside the range, below it.
By their numbers in this assay, from the lowest: compound 3; then compound 1; then compound 2.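

In this assay, a change of the phenyl on the amine nitrogen can remove the read-out altogether: 3,5-dichlorophenyl in place of 4-chlorophenyl gives a number 33 percentage points lower from compound 2 to compound 3 (beyond the scatter), and in place of 3-fluorophenyl it gives a number 17 percentage points lower from compound 1 to compound 3 (beyond the scatter). The earlier modest step therefore did not mark the limit of what a change here can do, and the higher number of the 4-chlorophenyl compound does not carry over to the 3,5-dichlorophenyl compound. Nothing measured here accounts for this drop. From the compounds shown here alone, whether the number of chlorines or their placement matters stays open, as does what a 3-chlorophenyl or a 4-methoxyphenyl would give on the shared core.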